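From compound 3 to compound 4: one chloro added

The source may hold more compounds than are shown below. What is called first, only, known or untested is meant among the compounds shown, and "the series" means these compounds.

Values measured in an ADME assay on HEK293 cells (Homo sapiens) for cytotoxicity, read by reporter gene assay and resazurin assay, with a stated time of 48 h (a lower number here means that less compound is tolerated, a higher number that more compound is tolerated), are as follows:
- Compound 1 `O=C(Nc1ccccc1)c1cc(Br)ccc1O` gives 35000 nM
- Compound 2 `COc1c(Br)cccc1C(=O)Nc1ccccc1` gives > 100000 nM as a limit
- Compound 3 `O=C(Nc1ccccc1)c1cccc(Br)c1` gives > 100000 nM as a limit

Compound 3 stands at the limit of > 100000 nM in this assay, at which 2 of the 3 values shown sit, and so offers a limit, not a number. Compound 4 `O=C(Nc1cccc(Cl)c1)c1cccc(Br)c1` differs from it by chloro in place of hydrogen on an aromatic carbon in one place, with chloro in place of hydrogen on an aromatic carbon. Both measured steps lie elsewhere in the structure. One shows an at least 2.8-fold higher number from compound 1 to compound 3 (0.45 log units; beyond the scatter) and the other shows a step that the two limits leave unreadable from compound 2 to compound 3 and neither sizes this change. For the measured compounds named here, compound 1 at 35000 nM shows only that a number can be reached in this set. A modest move to a lower number in this assay is therefore expected, and the estimate is an at least 1.2-fold lower number from compound 3 to compound 4 (0.09 log units; that floor lies within the scatter) for this change. Compound 4 is expected at 80000 nM within an estimated range from 30000 nM to 160000 nM in this account.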

Compound 4, half-maximal cytotoxic concentration: 51000 nM
Beside the measured number, compound 4's estimate is 1.6-fold (0.20 log units) above it; the range from low to high includes it.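

In this assay compound 4 gives 51000 nM, so chloro on an aromatic carbon, meta to a large group, yields a number without the hydroxy of compound 1. The change gives an at least 1.9-fold lower number from compound 3 to compound 4 (0.29 log units; that floor lies within the scatter), the first step shown on this position. That step remains only a floor because compound 3 carries a limit, not a number: the limit of > 100000 nM in this assay, at which 2 of the 4 values shown sit.

The compounds shown leave open whether fluoro or an amine at this position would move the number in the same way. They also leave open whether chloro would do so at another aromatic carbon.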